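A few compounds are considered here, and "the series" means these few. Any claim that something is new, unique, unknown or untested is made for them only; others in the source may bear on it.

Three compounds have been measured in a functional assay on PC-3 cells (Homo sapiens) for cytotoxicity; a higher number here means a weaker inhibitor of growth, a lower number a stronger inhibitor of growth:

Compound 1 `CC(C)(C)OC(=O)N1c2ccccc2CC1C(=O)Nc1cccc(C(F)(F)F)c1` gives 3340 nM.
Compound 2 `CC(C)(C)OC(=O)N1c2ccccc2CC1C(=O)Nc1ccc([N+](=O)[O-])cc1` gives 2790 nM.
Compound 3 `O=C(Nc1cc(C(F)(F)F)ccc1C(F)(F)F)C1Cc2ccccc2N1` gives 794 nM.

Compound 2 stands second highest of these three numbers. Its nearest neighbour is compound 1, whose number lies within the usual scatter of it, so the two cannot be told apart. Compound 3 is the furthest away, with a number lower than that of compound 2 by an amount beyond the scatter.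

Compound 4 `CC(C)(C)OC(=O)N1c2ccccc2CC1C(=O)Nc1ccc(C(F)(F)F)cc1` has not yet been measured in this assay. It differs from compound 2 in one place: trifluoromethyl in place of nitro on an aromatic carbon. Going by the values given here, no pair of measured compounds that differ in a single place is available, so the size of this step has not been seen directly. What can be said is that compound 1, which also carries a trifluoromethyl on its aromatic ring in place of a nitro, gives a number within the scatter of compound 2. On that basis no step beyond the scatter is expected in either direction, and the step from compound 2 to compound 4 is estimated at a 1.1-fold higher number from compound 2 to compound 4 (0.03 log units; within the scatter). Compound 4 is therefore expected to give about 3000 nM, within a range from 1200 nM to 7500 nM.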

Compound 4, concentration for 50% growth inhibition: 2020 nM
Estimate against measurement, compound 4: 1.5-fold (0.17 log units) above, and the stated range covers the measured number.
By their numbers in this assay, from the lowest: compound 3; then compounds 4, 2 and 1 (each within the scatter of the next).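

In this assay, putting trifluoromethyl in place of nitro on the aromatic carbon para to a large group gives a 1.4-fold lower number from compound 2 to compound 4 (0.14 log units; within the scatter). Going by these compounds alone, this is the first single-place change seen, and it shows that the two groups cannot be told apart at this position, although they share no atoms and only nitro counts hydrogen-bond acceptors. In this pair, then, those acceptors are not required to keep the number at this level, and nothing measured here explains why the exchange leaves it within the scatter.

As far as these compounds go, whether an amine or a carboxylic acid at this position would move the number beyond the scatter remains open, since both groups seen here leave it at much the same level. Also open, from the compounds shown here alone, is which feature sets compound 3, at 794 nM, apart from compound 2. Those two compounds differ in more than one place, and no single change can be credited with the gap between them.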